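The source may report more compounds than this note shows. Statements on the series, on what has been measured and on what is new or still open speak of the compounds shown alone.

Series notes. The shared core of compound 1 `Fc1cccc(-c2nc(Nc3ccc(Cl)cc3)c3cc(F)ccc3n2)c1` carries a 4-chlorophenyl on a nitrogen on an aromatic ring; in a functional assay on COLO 205 cells (Homo sapiens) for cytotoxicity, read by MTT assay, with a stated time of 48 h (on this read-out higher numbers stand for weaker inhibition and lower numbers for stronger inhibition), compound 1 gives 32600 nM. Compound 2 `Fc1cccc(-c2nc(Nc3ccccc3Br)c3cc(F)ccc3n2)c1` carries a 2-bromophenyl in the same place. In this assay compound 2 reaches only a limit of the assay, > 50000 nM, not a number. Compound 3 `Oc1cccc(Nc2nc(-c3cccc(F)c3)nc3ccc(F)cc23)c1` carries a 3-hydroxyphenyl. In this assay compound 3 also stands at a limit of the assay, > 50000 nM, so only a range is known for it. The step of an at least 1.5-fold higher number from compound 1 to compound 2 (0.18 log units; that floor lies within the scatter) and the step of an at least 1.5-fold higher number from compound 1 to compound 3 (0.18 log units; that floor lies within the scatter) are each read only as a floor; the step that the two limits leave unreadable from compound 2 to compound 3 cannot be read at all. Note (the limit of > 50000 nM in this assay, at which 2 of the 3 values shown sit). Compound 4 `Oc1ccccc1Nc1nc(-c2cccc(F)c2)nc2ccc(F)cc12` differs from compound 3 by 2-hydroxyphenyl in place of 3-hydroxyphenyl on a nitrogen on an aromatic ring. Among the compounds with values here, no measured step compares a 3-hydroxyphenyl with a 2-hydroxyphenyl; the only steps bearing on this place are the two floors from compound 1. In this assay the step of a number no higher from compound 3 to compound 4 (the limit leaves the size open) is expected to stay within the scatter, with no readable direction. Compound 4 is therefore estimated at 50000 nM, within 20000 nM to 150000 nM, most probably again reported only as a limit.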

Compound 4, half-maximal inhibitory concentration: > 50000 nM
Compound 4 was reported as a limit; the forecaster's own chance of this, stated with the estimate: 75%; the middle value lies on the limit itself.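

Moving the hydroxy group from the 3-hydroxyphenyl to the 2-hydroxyphenyl on this nitrogen yields no number in this assay, so neither hydroxyphenyl shown gives a measured value. The steps among compound 2, compound 3 and compound 4 cannot be read, because all three stand at the same limit: the limit of > 50000 nM in this assay, at which 3 of the 4 values shown sit.

Within the data shown here, the only readable step for the new compound is an at least 1.5-fold higher number from compound 1 to compound 4 (0.18 log units; that floor lies within the scatter), and this floor does not separate the 2-hydroxyphenyl from the 4-chlorophenyl beyond the scatter.

From the compounds shown here alone, how far compound 2, compound 3 and compound 4 lie past the limit, and whether they differ from one another, stays open. Also open, going by these compounds, is whether a 4-hydroxyphenyl or an aminophenyl on this nitrogen would return a number in this assay.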